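The source may hold more compounds than are shown below. What is called first, only, known or untested is meant among the compounds shown, and "the series" means these compounds.

Compound 1 `COc1ccc(N2CCN=C2c2ccc(C3=NCCN3c3ccc(OC)cc3)cc2)cc1` gives 361000 nM
Compound 2 `Fc1ccc(N2CCN=C2c2ccc(C3=NCCN3)cc2)cc1` gives > 971000 nM

In an ADME assay on MDCK cells (Canis lupus familiaris) for cytotoxicity, read by MTT assay, with a stated time of 24 h (a lower number here means that less compound is tolerated, a higher number that more compound is tolerated), compound 2 has only a limit, > 971000 nM as reported, and no number. Compound 3 `COc1ccc(N2CCN=C2c2ccc(C3=NCCN3)cc2)cc1` differs from compound 2 by one change, 4-fluorophenyl to 4-methoxyphenyl, counted as methoxy in place of fluoro on an aromatic carbon and placing methoxy in place of fluoro on an aromatic carbon, para to a large group. Within the data shown here, no measured pair of compounds isolates this change, so the only guide is compound 1, which also carries 4-methoxyphenyl and gives 361000 nM in this assay as a true number. The estimated step is an at least 1.3-fold lower number from compound 2 to compound 3 (0.14 log units; that floor lies within the scatter) and it is expected to be modest, towards less compound tolerated, and possibly no larger than the scatter. The estimated value for compound 3 is 700000 nM with a range of 300000 nM to 1500000 nM expected on measurement.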

Compound 3, half-maximal cytotoxic concentration: 224000 nM
For compound 3 the middle estimate is 3.1-fold (0.49 log units) above the measured one, and the stated range ends above it.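

In this assay, methoxy in place of fluoro on an aromatic carbon gives an at least 4.3-fold lower number from compound 2 to compound 3 (0.63 log units; beyond the scatter), so this position does respond to the change, and the step lies beyond the scatter. That step is only a floor because compound 2 carries a limit and not a number: the limit of > 971000 nM in this assay, at which 1 of the 3 values shown sits. The other step, a 1.6-fold lower number from compound 1 to compound 3 (0.21 log units; within the scatter) for hydrogen in place of 4-methoxyphenyl on an amine nitrogen in a ring, stays within the scatter, so the added 4-methoxyphenyl of compound 1 has no effect that can be read in this assay.

Going by these compounds, the true size of the step to compound 3 remains open. So does whether a hydroxy group, an amine or a longer alkoxy chain in place of fluoro would behave as methoxy does.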